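Solubility in the benzoyl-urea series: compound 3 estimate

This account rests on a few compounds, and the source may have more. Where it says the series, first, only, none or still open, it means among the compounds named here.

Measured so far:
compound 1, `COc1ccccc1C(=O)NC(=O)Nc1ccc(-c2nccs2)c(C(F)(F)F)c1`: 12 ug/mL
compound 2, `COc1ccccc1C(=O)NC(=O)Nc1ccc(N2CCCCC2)c(C(F)(F)F)c1`: 4.1 ug/mL

Among the measured compounds shown here, in a physicochemical assay for solubility, in simulated intestinal fluid (on this read-out lower numbers stand for lower solubility and higher numbers for higher solubility), compound 2 gives 4.1 ug/mL, the lowest of the two numbers so far; its nearest neighbour is compound 1, which in this assay gives 12 ug/mL. For the measured compounds named here, the one measured step, a 2.9-fold lower number from compound 1 to compound 2 (0.47 log units; beyond the scatter), is the exchange of 1,3-thiazol-2-yl for piperidin-1-yl on an aromatic carbon.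

Compound 3, `COc1ccccc1C(=O)NC(=O)Nc1ccc(C(C)C)c(C(F)(F)F)c1`, differs from compound 2 in one place: isopropyl in place of piperidin-1-yl on an aromatic carbon. Going by the values given here, no measured step bears on this change directly; the step from compound 1 to compound 2 concerns a different pair of groups at the same carbon and offers no guide for isopropyl. The expectation therefore rests on compound 2 alone, whose value in this assay is 4.1 ug/mL, and on the absence of any measured step at this position that moved the number upward from that level. The estimate for compound 3 in this assay is 3 ug/mL, with a range of 1 ug/mL to 10 ug/mL, which would mean an expected step of a 1.4-fold lower number from compound 2 to compound 3 (0.14 log units; within the scatter), within the scatter.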

Compound 3, solubility: 6.9 ug/mL
For compound 3 the middle estimate is 2.3-fold (0.36 log units) below the measured one; the measured number falls inside the stated range.
By their numbers in this assay, from the lowest: compounds 2, 3 and 1 (each within the scatter of the next, the first and the last beyond it).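

In this assay the exchange for isopropyl gives a 1.7-fold higher number from compound 2 to compound 3 (0.23 log units; within the scatter) and, against the thiazole, a 1.7-fold lower number from compound 1 to compound 3 (0.24 log units; within the scatter) so compound 3 cannot be separated from either neighbour, although the two ring-bearing compounds are separated by a 2.9-fold lower number from compound 1 to compound 2 (0.47 log units; beyond the scatter) at the same carbon. This aromatic carbon, ortho to a trifluoromethyl group and para to a large group, therefore carries an open-chain group of carbon only, with no ring and no hydrogen-bond acceptor, and the number stays in the same range as with the two ring-bearing groups; with three compounds, the data show no clear order for isopropyl against either ring and only the gap between compound 1 and compound 2 can be read. Nothing at hand explains why any of these numbers falls where it does.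

Open, as far as these compounds go, is how a morpholin-4-yl ring, a dimethylamino group or a carboxylic acid on this carbon would read in this assay, and whether a longer alkyl chain would stay level with isopropyl. Also open, from the compounds shown here alone, is whether these readings would hold if a nitrile took the place of the trifluoromethyl group.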